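Dimethoxy versus trimethoxy pairs in a dienone series

The source may report more compounds than this note shows. Statements on the series, on what has been measured and on what is new or still open speak of the compounds shown alone.

Measured compounds:
compound 1 `COc1ccc(/C=C2\CCC/C(=C\c3cccc(OC)c3OC)C2=O)cc1`: 43500 nM
compound 2 `COc1ccc(/C=C2\CCC/C(=C\c3cccc(OC)c3OC)C2=O)cc1OC`: 14900 nM
compound 3 `COc1ccc(/C=C2\CCC/C(=C\c3ccc(OC)c(OC)c3)C2=O)cc1`: 30900 nM

In an ADME assay on NHDF cells (Homo sapiens) for cytotoxicity, read by MTT assay, with a stated time of 72 h (on this read-out higher numbers stand for weaker inhibition and lower numbers for stronger inhibition), compound 1 gives 43500 nM and compound 2 gives 14900 nM; the step of a 2.9-fold lower number from compound 1 to compound 2 (0.47 log units; beyond the scatter) is made by the change (methoxy in place of hydrogen on an aromatic carbon). The same atoms as in compound 1 are joined differently in compound 3, and in this assay compound 3 gives 30900 nM; the difference between the two cores is not broken down here. Compound 4 `COc1ccc(/C=C2\CCC/C(=C\c3ccc(OC)c(OC)c3)C2=O)cc1OC` is unmeasured and differs from compound 3 by methoxy in place of hydrogen on an aromatic carbon, the same change as from compound 1 to compound 2. Resting on that earlier step, the expected step is a 2.8-fold lower number from compound 3 to compound 4 (0.45 log units; beyond the scatter) in this assay. Compound 4 is estimated at 11000 nM in this assay, between 5000 nM and 25000 nM.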

Compound 4, half-maximal inhibitory concentration: 9700 nM
Compound 4: the middle estimate sits 1.1-fold (0.05 log units) above what was measured; low and high end bracket the measured number.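

In this assay, methoxy in place of hydrogen on an aromatic carbon gives a 3.2-fold lower number from compound 3 to compound 4 (0.50 log units; beyond the scatter), and this step matches the earlier one on the other core: the same change on two cores in this assay, a 2.9-fold lower number (0.47 log units; beyond the scatter) from compound 1 to compound 2 and a 3.2-fold lower number (0.50 log units; beyond the scatter) from compound 3 to compound 4, 1.1-fold (0.04 log units) apart, within the scatter of two such steps. The agreement rests on two pairs only, and in both the methoxy enters ortho to a methoxy group, so it shows the change carrying between these two cores and not to any other core or place. It gives no reason for the size of the step and applies only to this assay.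

On these data alone, whether an amine, a hydroxyl or a longer chain such as ethoxy in the same place would give a step of similar size remains open. Also open, as far as these compounds go, is whether the step holds when the methoxy enters on the other aromatic ring.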